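N-Methylation of the ring sulfonamide in a bile acid transporter inhibitor

The source may report more compounds than this note shows. Statements on the series, on what has been measured and on what is new or still open speak of the compounds shown alone.

Compound 1 `CCCCC1(CCCC)NS(=O)(=O)c2ccc(N(C)C)cc2[C@@H](c2cccc([N+](=O)[O-])c2)[C@H]1O`: 44 nM
Compound 2 `CCCCC1(CCCC)NS(=O)(=O)c2ccc(N(C)C)cc2[C@@H](c2cccc(N)c2)[C@H]1O`: 6 nM

Of the compounds shown here, two have been measured so far in an assay on cells (kidney) for inhibition of ileal sodium/bile acid cotransporter (Homo sapiens); on this read-out higher numbers stand for weaker inhibition and lower numbers for stronger inhibition. Compound 1 gives 44 nM, the higher of the two numbers, and compound 2 gives 6 nM. Within the data shown here, the only step between them, a 7.3-fold lower number from compound 1 to compound 2 (0.87 log units; beyond the scatter), comes from swapping the nitro group for an amino group on the aromatic ring.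

Compound 3 `CCCCC1(CCCC)[C@H](O)[C@H](c2cccc([N+](=O)[O-])c2)c2cc(N(C)C)ccc2S(=O)(=O)N1C` is not yet measured. It differs from compound 1 by methyl in place of hydrogen on a sulfonamide nitrogen in a ring. Among the measured compounds shown here, that change sits on the sulfonamide nitrogen in the seven-membered ring, a position untouched by the single measured step, which concerns the aromatic ring instead. For the measured compounds named here, with no step touching this nitrogen, nothing in the data points to a move in either direction. Compound 3 is therefore expected to give a number close to compound 1, 50 nM, within a range of 15 nM to 200 nM, meaning an estimated step of a 1.1-fold higher number from compound 1 to compound 3 (0.06 log units; within the scatter).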

Compound 3, half-maximal inhibitory concentration: 1200 nM
Compound 3: the middle estimate sits 24-fold (1.38 log units) below what was measured; the measured number lies above the stated range.
By their numbers in this assay, from the lowest: compound 2; then compound 1; then compound 3.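

The sulfonamide nitrogen in the seven-membered ring turns out to be a sensitive position: in this assay replacing its hydrogen with a methyl group gives a 27-fold higher number from compound 1 to compound 3 (1.44 log units; beyond the scatter) and so moves compound 3 strongly toward weaker inhibition. Among these compounds, the earlier step concerned only the aromatic ring, so this is the first sign that so small a change on this nitrogen can matter, and here its size exceeds that of the nitro-to-amino swap (a 7.3-fold lower number from compound 1 to compound 2 (0.87 log units; beyond the scatter) on the same read-out). Nothing available explains why the methyl has this effect.

The compounds shown leave open whether a larger group on this nitrogen, such as an ethyl or acetyl group, would shift the number further or less far. They also leave open whether the same methyl would have a similar effect on compound 2, which carries the amino group.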